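Adding a Single Chloro to the Phenyl Ring

The source may report more compounds than this note shows. Statements on the series, on what has been measured and on what is new or still open speak of the compounds shown alone.

Three analogues of one core have been measured in a functional assay on SW-620 cells (Homo sapiens) for cytotoxicity, read by sulforhodamine B assay, with a stated time of 48 h; on this read-out higher numbers stand for weaker inhibition and lower numbers for stronger inhibition. Compound 1 `C[C@H]1CC[C@@H]2[C@@H](OC(=O)[C@]23CC(c2c(Cl)cccc2Cl)=NO3)[C@]2(C)C(=O)C=C[C@@]12O` gives 43000 nM, compound 2 `C[C@H]1CC[C@@H]2[C@@H](OC(=O)[C@]23CC(c2ccccc2)=NO3)[C@]2(C)C(=O)C=C[C@@]12O` gives 45400 nM, and compound 3 `C[C@H]1CC[C@@H]2[C@@H](OC(=O)[C@]23CC(c2cccc([N+](=O)[O-])c2)=NO3)[C@]2(C)C(=O)C=C[C@@]12O` gives 49000 nM. Compound 2 sits among them with a 1.1-fold higher number from compound 1 to compound 2 (0.02 log units; within the scatter) and a 1.1-fold higher number from compound 2 to compound 3 (0.03 log units; within the scatter); the remaining step, a 1.1-fold higher number from compound 1 to compound 3 (0.06 log units; within the scatter), is equally small. Compound 4 `C[C@H]1CC[C@@H]2[C@@H](OC(=O)[C@]23CC(c2ccccc2Cl)=NO3)[C@]2(C)C(=O)C=C[C@@]12O` differs from compound 2 by chloro in place of hydrogen on an aromatic carbon. Among the measured compounds shown here, the nearest precedent is the change from 2,6-dichlorophenyl to phenyl, a 1.1-fold higher number from compound 1 to compound 2 (0.02 log units; within the scatter), which stayed within the scatter, as did the nitro step a 1.1-fold higher number from compound 2 to compound 3 (0.03 log units; within the scatter). Compound 4 is therefore expected to show no step beyond the scatter, a 1.0-fold lower number from compound 2 to compound 4 (0.00 log units; within the scatter). Compound 4 is estimated at 45000 nM, with a range from 25000 nM to 80000 nM.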

Compound 4, half-maximal inhibitory concentration: 9000 nM
For compound 4 the middle estimate is 5.0-fold (0.70 log units) above the measured one; measured number outside the range, below it.
By their numbers in this assay, from the lowest: compound 4; then compounds 1, 2 and 3 (each within the scatter of the next).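

Chloro in place of hydrogen, ortho to a large group, is the first change on this ring to move the number beyond the scatter in this assay (a 5.0-fold lower number from compound 2 to compound 4 (0.70 log units; beyond the scatter)), and replacing 3-nitrophenyl with 2-chlorophenyl does the same (a 5.4-fold lower number from compound 3 to compound 4 (0.74 log units; beyond the scatter)). The effect does not build with a second chloro: 2-chlorophenyl also stands apart from 2,6-dichlorophenyl (a 4.8-fold lower number from compound 1 to compound 4 (0.68 log units; beyond the scatter)), whose number lies within the scatter of the unsubstituted phenyl. Nothing available explains this difference. Going by these compounds, whether a bromo, methyl or methoxy group ortho to a large group behaves like chloro remains open. So does whether a single chloro elsewhere on the ring keeps the step.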